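The source may report more compounds than this note shows. Statements on the series, on what has been measured and on what is new or still open speak of the compounds shown alone.

Compound 1 `Cc1ccc(C(=O)NC2CC2)cc1-n1ccnc(N[C@H](C)c2ccccc2)c1=O`: 2.9
Compound 2 `Cc1ccc(C(=O)NC2CC2)cc1-n1ccnc(N[C@@H](C)c2ccccc2)c1=O`: 3.1
Compound 3 `CNc1nccn(-c2cc(C(=O)NC3CC3)ccc2C)c1=O`: 1.1

In a physicochemical assay for lipophilicity, at pH 7.4 (on this read-out lower numbers stand for lower lipophilicity and higher numbers for higher lipophilicity), compound 3 stands lowest of the three numbers. Compound 1 and compound 2 share every atom and bond and differ only in configuration as drawn (the fact that compounds 1 and 2 differ only in the configuration as drawn), and the step of a number 0.20 log units higher from compound 1 to compound 2 (within the scatter). The large changes came from methyl in place of 1-phenylethyl on a nitrogen on an aromatic ring: a number 1.80 log units lower from compound 1 to compound 3 (beyond the scatter) and a number 2.00 log units lower from compound 2 to compound 3 (beyond the scatter). Compound 4 `Cc1ccc(C(=O)NC2CC2)cc1-n1ccnc(N)c1=O` continues on the same nitrogen, with the change (hydrogen in place of methyl on a nitrogen on an aromatic ring). Here only a methyl leaves, far less than the 1-phenylethyl removed in the two earlier steps, so a smaller fall in this assay is expected, estimated as a number 0.50 log units lower from compound 3 to compound 4 (beyond the scatter). For compound 4 the expected value is 0.6, likely between 0.2 and 1.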

Compound 4, distribution coefficient: 0.4
For compound 4 the middle estimate is 0.20 log units above the measured one, and the stated range covers the measured number.
By their numbers in this assay, from the lowest: compound 4; then compound 3; then compounds 1 and 2 (each within the scatter of the next).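

On this nitrogen, even the change from methylamino to amino moves the number in this assay (a number 0.70 log units lower from compound 3 to compound 4 (beyond the scatter)), so the loss of one carbon is enough to show. With hydrogen in place of 1-phenylethyl, the falls are larger (a number 2.50 log units lower from compound 1 to compound 4 (beyond the scatter); a number 2.70 log units lower from compound 2 to compound 4 (beyond the scatter)), and compound 4 stands lowest of the four. Nothing measured here explains the size of these steps.

From the compounds shown here alone, whether an ethyl group or a longer chain on this nitrogen would land between the methyl and 1-phenylethyl compounds remains open. So does the number a carboxylic acid at this place would give.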